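Swapping a five-membered ring for a pyridine on the amine

This account rests on a few compounds, and the source may have more. Where it says the series, first, only, none or still open, it means among the compounds named here.

Of the compounds shown here, two share a core and have been measured in a functional assay for antagonist activity at integrin alpha-5/beta-1 (Homo sapiens), read by ELISA; on this read-out higher numbers stand for weaker inhibition and lower numbers for stronger inhibition. Compound 1 `Cc1cc(C)c(S(=O)(=O)N[C@@H](CNC(=O)C2=NO[C@]3(C2)C[C@@H](CNc2ncc[nH]2)N(C(=O)OCc2ccccc2)C3)C(=O)O)c(C)c1` gives 18 nM in this assay. Compound 2 `Cc1cc(C)c(S(=O)(=O)N[C@@H](CNC(=O)C2=NO[C@]3(C2)C[C@@H](CNC2N=CC=N2)N(C(=O)OCc2ccccc2)C3)C(=O)O)c(C)c1` gives 13 nM in this assay, which is the lower of the two numbers, though the two lie within the scatter of each other. Going by the values given here, the one step that has been measured, a 1.4-fold lower number from compound 1 to compound 2 (0.14 log units; within the scatter), shows that exchanging one small ring on the amine nitrogen for another of the same size did not move the number beyond the scatter.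

Compound 3 `Cc1cc(C)c(S(=O)(=O)N[C@@H](CNC(=O)C2=NO[C@]3(C2)C[C@@H](CNc2ccccn2)N(C(=O)OCc2ccccc2)C3)C(=O)O)c(C)c1` is not yet measured. It differs from compound 2 in one place: a group of 6 heavy atoms (5 carbon, 1 nitrogen; one six-membered aromatic ring with 1 hetero atom) in place of a group of 5 heavy atoms (3 carbon, 2 nitrogen; one five-membered non-aromatic ring with 2 hetero atoms), on an amine nitrogen. This change is of a similar kind to the measured step, a small ring replaced by another small ring on the same amine nitrogen, and that step stayed within the scatter. Because the change from compound 1 to compound 2 was a 1.4-fold lower number from compound 1 to compound 2 (0.14 log units; within the scatter), compound 3 is expected to show a step of about a 1.5-fold higher number from compound 2 to compound 3 (0.19 log units; within the scatter) in this assay, which is no movement beyond the scatter. For compound 3 the estimate in this assay is 20 nM, with a range from 7 nM to 60 nM.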

Compound 3, half-maximal inhibitory concentration: 0.18 nM
For compound 3 the middle estimate is 110-fold (2.05 log units) above the measured one, and the stated range ends above it.
By their numbers in this assay, from the lowest: compound 3; then compounds 2 and 1 (each within the scatter of the next).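

In this assay, this amine nitrogen proves far from indifferent to the ring it carries: pyridin-2-yl in place of the five-membered non-aromatic ring gives a 72-fold lower number from compound 2 to compound 3 (1.86 log units; beyond the scatter) and, in place of 1H-imidazol-2-yl, it gives a 100-fold lower number from compound 1 to compound 3 (2.00 log units; beyond the scatter) on the same scale. The two five-membered rings lie within the scatter of each other, so they made this place look tolerant of ring exchange, whereas the six-membered aromatic ring shows that a single exchange here can shift inhibition by a large margin. With both of its steps beyond the scatter, compound 3 is the strongest inhibitor of the three, and the rest of its structure is the same as in compound 1 and compound 2.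

No measurement shown here explains the size of this shift. Ring size, aromatic character and the count of ring nitrogens all differ together in these exchanges, and a phenyl ring or a pyrimidin-2-yl group on the same amine nitrogen would be needed to begin pulling them apart.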